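The source may hold more compounds than are shown below. What is called first, only, known or untested is meant among the compounds shown, and "the series" means these compounds.

Of the compounds shown here, two have been measured in a functional assay on MGC-803 cells (Homo sapiens) for antiproliferative activity, read by MTT assay, with a stated time of 48 h; a lower number here means a stronger inhibitor, a higher number a weaker inhibitor. Compound 1 `COc1ccc(CN(C(=O)CSc2nc3ccccc3s2)c2cc(OC)c(OC)c(OC)c2)cc1C` gives 6360 nM, and compound 2 `COc1ccc(CN(C(=O)CSc2nc3ccccc3s2)c2cc(OC)c(OC)c(OC)c2)cc1` gives 163 nM. Compound 2 therefore stands with the lowest of the two numbers, its nearest neighbour being compound 1 at a 39-fold lower number from compound 1 to compound 2 (1.59 log units; beyond the scatter), a step made by hydrogen in place of methyl on an aromatic carbon.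

Compound 3 `COc1ccc(CN(C(=O)CSc2nc3ccccc3s2)c2cc(OC)c(OC)c(OC)c2)cc1OC` is not yet measured. It differs from compound 2 in one place: methoxy in place of hydrogen on an aromatic carbon. Among the measured compounds shown here, the one measured step that bears on this is a 39-fold lower number from compound 1 to compound 2 (1.59 log units; beyond the scatter), where a small group on an aromatic carbon went with a far higher number. The entering methoxy is a different group from that methyl, so the step cannot simply be copied, but it points in the same direction, and compound 3 is expected to sit a 4.3-fold higher number from compound 2 to compound 3 (0.63 log units; beyond the scatter) in this assay, above compound 2. His estimate for compound 3 is 700 nM, with a range from 150 nM to 3500 nM.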

Compound 3, half-maximal inhibitory concentration: 34100 nM
Beside the measured number, compound 3's estimate is 49-fold (1.69 log units) below it; the whole stated range lies below it.
By their numbers in this assay, from the lowest: compound 2; then compound 1; then compound 3.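

In this assay, the place on the 4-methoxybenzyl ring ortho to a methoxy group has now been read with three occupants, and hydrogen gives the lowest number: methoxy there brings a 210-fold higher number from compound 2 to compound 3 (2.32 log units; beyond the scatter), a step even larger than the one seen earlier with methyl, a 39-fold lower number from compound 1 to compound 2 (1.59 log units; beyond the scatter). The result also shows that the two small groups are not equivalent at this place, since methoxy in place of methyl gives a 5.4-fold higher number from compound 1 to compound 3 (0.73 log units; beyond the scatter), so the order among these three compounds runs from hydrogen through methyl to methoxy, and none of them goes against it. Nothing at hand shows why this single position responds so sharply to either group.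

The compounds shown leave open whether a fluorine, a chlorine, a hydroxyl or an amine at this same place would stay close to compound 2 or climb as compound 1 and compound 3 do. They also leave open how much the 4-methoxy group itself matters, as all three compounds carry it, and whether an ethoxy there would change the picture.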